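Cytotoxicity notes: the step from compound 2 to compound 4

The source may report more compounds than this note shows. Statements on the series, on what has been measured and on what is new or still open speak of the compounds shown alone.

Three members of the series have been tested in an ADME assay on HELF cells (Homo sapiens) for cytotoxicity, with a stated time of 3 days; a higher number here means that more compound is tolerated, a lower number that less compound is tolerated. Compound 1 `C[C@H](NC(=O)[C@]1(Cc2ccccc2)CCN1C(=O)OCc1ccc([N+](=O)[O-])cc1)C(N)=O` gives 100000 nM. Compound 2 `C[C@H](NC(=O)[C@]1(Cc2ccccc2)CCN1C(=O)OCc1ccccc1)C(=O)N(C)C` returns only a limit of the assay, > 100000 nM. Compound 3 `C[C@H](NC(=O)[C@]1(Cc2ccccc2)CCN1S(=O)(=O)c1ccc2ccccc2c1)C(N)=O` likewise returns only a limit, > 100000 nM. The picture so far is therefore (the limit of > 100000 nM in this assay, at which 2 of the 3 values shown sit), with compound 1 sitting at the same concentration as a plain number. No two of these compounds differ in a single place, so no measured step can be drawn from them, and the values themselves show a series that is uniformly well tolerated at the top of the tested range.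

Compound 4 `C[C@H](NC(=O)[C@]1(Cc2ccccc2)CCN1C(=O)OCc1ccccc1)C(=O)NCc1ccccc1` is not yet measured. It differs from compound 2 by benzylamino in place of dimethylamino on a carbonyl carbon. With compound 2 at the limit and every other value at or beyond the same concentration, the step from compound 2 to compound 4 in this assay is expected to be none beyond the scatter, most likely another limit. For compound 4 the estimated value is 100000 nM, within a range from 50000 nM to 200000 nM, which corresponds to an expected step of a number no higher from compound 2 to compound 4 (the limit leaves the size open).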

Compound 4, minimum cytotoxic concentration: 100000 nM
Beside the measured number, compound 4's estimate shows no gap at the digits printed, within the range that was stated.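

Going by these compounds alone, the change on this carbonyl carbon gives the first comparison that differs in one place: in this assay, with benzylamino in place of dimethylamino, the result is a number no higher from compound 2 to compound 4 (the limit leaves the size open). The size of that step cannot be read because one of its ends is a limit of the assay: the limit of > 100000 nM in this assay, at which 2 of the 4 values shown sit. The pair does show that this position can carry a group with a six-membered aromatic ring and a hydrogen-bond donor, with compound 4 still reading 100000 nM.

Open, from the compounds shown here alone, is whether a carboxylic acid at this carbonyl carbon, or a longer chain such as phenethylamino, would read the same. The compounds shown give no plain number away from this concentration, so no group is yet tied to a lower value.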